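A few compounds are considered here, and "the series" means these few. Any claim that something is new, unique, unknown or untested is made for them only; others in the source may bear on it.

Within the data shown here, in a functional assay on A549 cells (Homo sapiens) for antiproliferative activity, read by MTT assay, with a stated time of 72 h, in the presence of a further agent that is not named here (on this read-out lower numbers stand for stronger inhibition and higher numbers for weaker inhibition), compound 1 (`Nc1nc2[nH]c(CCSCCC(=O)N[C@@H](CCC(=O)O)C(=O)O)cc2c(=O)[nH]1`) gives 713 nM and so holds the lower of the two numbers measured so far. Compound 2 (`Nc1nc2[nH]c(CCSCC(=O)NCc3cccnc3)cc2c(=O)[nH]1`) gives 56600 nM and stands beyond the scatter on the weaker side. Compound 3 (`Nc1nc2[nH]c(CCSCCC(=O)NCc3cccnc3)cc2c(=O)[nH]1`) departs from compound 1 at one place, with (pyridin-3-yl)methyl in place of 1,3-dicarboxypropyl on an amide-type nitrogen. Among the measured compounds shown here, no measured pair shows this change alone. The nearest guide is compound 2 at 56600 nM as it also carries (pyridin-3-yl)methyl on an amide-type nitrogen, although its chain differs from that of compound 3. A large upward step towards weaker inhibition in this assay is therefore expected, beyond the scatter (estimated as a 35-fold higher number from compound 1 to compound 3 (1.54 log units; beyond the scatter)). The estimated value for compound 3 is 25000 nM (expected range 6000 nM to 100000 nM).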

Compound 3, half-maximal inhibitory concentration: 1070 nM
Beside the measured number, compound 3's estimate is 23-fold (1.37 log units) above it; the whole stated range lies above it.
By their numbers in this assay, from the lowest: compounds 1 and 3 (each within the scatter of the next); then compound 2.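

In this assay, putting (pyridin-3-yl)methyl in place of 1,3-dicarboxypropyl on the amide-type nitrogen gives a 1.5-fold higher number from compound 1 to compound 3 (0.18 log units; within the scatter). At this position, then, the group that leaves, with its two carboxylic acids and its defined stereocentre, is not required for a number in this range: a group with one six-membered aromatic ring and no stereocentre stands level with it within the scatter. Nothing at hand explains why these two different groups read alike.

The compounds shown leave open whether this tolerance extends to other groups on this nitrogen, such as benzyl, which lacks the ring nitrogen, or a group carrying a single carboxylic acid. They also leave open whether a longer chain bearing this amide would keep a number in this range.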